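N-Methylation of a piperidine ring at the shared core

The source may report more compounds than this note shows. Statements on the series, on what has been measured and on what is new or still open speak of the compounds shown alone.

Measured compounds:
- compound 1, `CN1CCC(n2cc(S(=O)(=O)c3ccc(F)cc3)c3cccnc32)C1`, in a functional assay on HeLa cells for antagonist activity at 5-hydroxytryptamine receptor 6 (Homo sapiens), read by cAMP accumulation and immunoassay (on this read-out higher numbers stand for weaker inhibition and lower numbers for stronger inhibition), compound 1 gives 213 nM
- compound 2, `CN1CCC(n2cc(S(=O)(=O)c3ccc(Cl)cc3)c3cccnc32)C1`, in this assay compound 2 gives 95 nM
- compound 3, `O=S(=O)(c1ccc(Cl)cc1)c1cn(C2CCCNC2)c2ncccc12`, in this assay compound 3 gives 682 nM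

Among these three, compound 3 stands with the highest number, that is, as the weakest inhibitor; its steps to compound 1 and to compound 2 both lie beyond the scatter. The swap of fluoro for chloro gave a 2.2-fold lower number from compound 1 to compound 2 (0.35 log units; beyond the scatter), and the change of the ring on the aromatic nitrogen gave a 7.2-fold higher number from compound 2 to compound 3 (0.86 log units; beyond the scatter).

Compound 4, `CN1CCCC(n2cc(S(=O)(=O)c3ccc(Cl)cc3)c3cccnc32)C1`, differs from compound 3 by methyl in place of hydrogen on an amine nitrogen in a ring. Among the measured compounds shown here, no measured step reports this change alone; the nearest is the step from compound 2 to compound 3, where loss of a methyl came together with a change of ring size. Part of that loss is therefore expected to be recovered, so a lowering in this assay of about a 2.7-fold lower number from compound 3 to compound 4 (0.44 log units; beyond the scatter) is estimated. For compound 4 a value of 250 nM is expected, between 80 nM and 700 nM.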

Compound 4, half-maximal inhibitory concentration: 28 nM
Compound 4: the middle estimate sits 8.9-fold (0.95 log units) above what was measured; measured number outside the range, below it.
By their numbers in this assay, from the lowest: compound 4; then compound 2; then compound 1; then compound 3.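

In this assay, methyl in place of hydrogen on the ring nitrogen gives a 24-fold lower number from compound 3 to compound 4 (1.39 log units; beyond the scatter) and so, taken alone, has a large effect at this position. With that methyl present on both compounds, the ring change from 1-methylpyrrolidin-3-yl to 1-methylpiperidin-3-yl gives a 3.4-fold lower number from compound 2 to compound 4 (0.53 log units; beyond the scatter) and thus goes towards stronger inhibition, which shows that the six-membered ring does not by itself account for a 7.2-fold higher number from compound 2 to compound 3 (0.86 log units; beyond the scatter) when the methyl is absent. The data shown give no reason for the size of these steps.

From the compounds shown here alone, whether an ethyl or a 2-hydroxyethyl group on the same nitrogen would keep the lower number remains open. So does whether the methyl would have a similar effect with fluoro in place of chloro on the aromatic ring.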